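The compounds below may be only part of what the source reports. "The series", "measured", "known", "first", "only" and "open" are said of these compounds alone.

In an assay on HEK293 cells for antagonist activity at Toll-like receptor 9 (Homo sapiens), read by spectrophotometry (a lower number here means a stronger inhibitor, a higher number a weaker inhibitor), compound 1 `CCN1CCN(CCCn2cnc3c(N4CCN(C5CCCC5)CC4)nc(NCc4ccc(F)cc4)nc32)CC1` gives 250 nM. Compound 2 `CCN1CCN(CCCn2cnc3c(N4CCN(C5CCCC5)CC4)nc(N)nc32)CC1` carries hydrogen in place of 4-fluorobenzyl on a nitrogen on an aromatic ring, and in this assay compound 2 gives 280 nM, a step of a 1.1-fold higher number from compound 1 to compound 2 (0.05 log units; within the scatter). Compound 3 `CCN1CCN(CCCn2cnc3c(N4CCN(C(=O)C5CCCC5)CC4)nc(NCc4ccc(F)cc4)nc32)CC1` has a different core, the difference being (cyclopentylcarbonyl in place of cyclopentyl on an amine nitrogen in a ring). For compound 3 this assay reports only a limit, > 30000 nM. The resulting step, an at least 120-fold higher number from compound 1 to compound 3 (2.07 log units; beyond the scatter), rests on (the limit of > 30000 nM in this assay, at which 1 of the 3 values shown sits). Compound 4 `CCN1CCN(CCCn2cnc3c(N4CCN(C(=O)C5CCCC5)CC4)nc(N)nc32)CC1` is not yet measured; it differs from compound 3 by hydrogen in place of 4-fluorobenzyl on a nitrogen on an aromatic ring, the same change as from compound 1 to compound 2, at the same place. Because that earlier step was a 1.1-fold higher number from compound 1 to compound 2 (0.05 log units; within the scatter), the step from compound 3 to compound 4 in this assay is expected to be similarly small, about a step that the limit leaves unreadable from compound 3 to compound 4. Compound 4 is therefore estimated at 60000 nM, most likely again reported only as a limit.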

Compound 4, half-maximal inhibitory concentration: > 30000 nM
Compound 4 gave a limit, no number (the forecaster's own chance of this, stated with the estimate: 80%); the middle value does not contradict the limit.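

In this assay, the change from cyclopentyl to cyclopentylcarbonyl on the amine nitrogen in a ring also carries over to the core without the 4-fluorobenzyl group, with an at least 100-fold higher number from compound 2 to compound 4 (2.02 log units; beyond the scatter). Set side by side, the two steps run the same way, but their sizes can be compared only this far: the same change on two cores in this assay, an at least 120-fold higher number (2.07 log units; beyond the scatter) from compound 1 to compound 3 and an at least 100-fold higher number (2.02 log units; beyond the scatter) from compound 2 to compound 4; the limit leaves it open whether they differ. Going by these compounds, the step from compound 3 to compound 4 cannot be read, so the effect of losing 4-fluorobenzyl on the cyclopentylcarbonyl core stays unknown, and the comparison rests on a single limit: the limit of > 30000 nM in this assay, at which 2 of the 4 values shown sit.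

On these data alone, it remains open whether an acetyl or a cyclohexyl group on that amine nitrogen would stay near compound 1 or also reach the limit. Also open, as far as these compounds go, is how a methyl group in place of 4-fluorobenzyl would read on either core.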